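The source may hold more compounds than are shown below. What is called first, only, known or untested is meant among the compounds shown, and "the series" means these compounds.

The measured compounds: compound 1 `CCOc1cc(C)c(-c2cccc(COc3ccc(OCC(=O)O)c(F)c3)c2)c(C)c1`, compound 2 `Cc1cc(OCC(=O)N(C)C)cc(C)c1-c1cccc(COc2ccc(OCC(=O)O)c(F)c2)c1` and compound 3 `Cc1cc(OCC(=O)N2CCOCC2)cc(C)c1-c1cccc(COc2ccc(OCC(=O)O)c(F)c2)c1`.

In a functional assay on CHO cells for agonist activity at Free fatty acid receptor 1 (Homo sapiens), read by FLIPR and calcium flux (on this read-out lower numbers stand for an effect already at smaller amounts and higher numbers for an effect only at larger amounts of compound), compound 1 gives 65.9 nM. For compound 2 the result in this assay is "not determined" (no result reported). For compound 3 the result in this assay is likewise "not determined" (no result reported), so compound 3 stands without a number, as does one further compound of the set. The step to compound 4 `COCCOc1cc(C)c(-c2cccc(COc3ccc(OCC(=O)O)c(F)c3)c2)c(C)c1` is methoxymethyl in place of (morpholin-4-yl)carbonyl on a saturated chain carbon bound to an oxygen on an aromatic ring. Since compound 3 has no value in this assay, no size or direction can be read for this step; compound 4 can only be set beside compound 1, whose ether chain differs from that of compound 4 by a single methoxy. Compound 4 is therefore expected to give about 90 nM in this assay, estimated between 30 nM and 300 nM.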

Compound 4, half-maximal effective concentration: 104 nM
Compound 4: the middle estimate sits 1.2-fold (0.06 log units) below what was measured; the range from low to high includes it.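

In this assay, methoxy in place of hydrogen on a saturated chain carbon, two bonds along the chain from an oxygen on an aromatic ring, gives a 1.6-fold higher number from compound 1 to compound 4 (0.20 log units; within the scatter), so this position holds the 2-methoxyethoxy chain with no change beyond the scatter. The steps from compound 2 and compound 3 cannot be read, which leaves the (morpholin-4-yl)carbonyl group without a comparison. Nothing measured here explains the result. The compounds shown leave open how a longer chain, an amine or a carboxylic acid at the end of this ether chain would read.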